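Swapping the aryl group on the sulfonyl of compound 2

This account rests on a few compounds, and the source may have more. Where it says the series, first, only, none or still open, it means among the compounds named here.

Measured compounds:
Compound 1, `CC1CCN(c2c(S(=O)(=O)c3cc(Cl)cc(Cl)c3)cnc3ccc(F)cc23)CC1`, gives 69% in an assay on isolated protein for displacement of a labelled ligand from metabotropic glutamate receptor 5 (Homo sapiens), with a stated time of 60 min, tested at 1 uM; a higher number here means more inhibition at the concentration tested (going by the name of the read-out), a lower number less inhibition.
Compound 2, `CC1CCN(c2c(S(=O)(=O)c3ccc(F)c(F)c3)cnc3ccc(F)cc23)CC1`, gives 82% in this assay.

Among the measured compounds shown here, of the two measured numbers, compound 2 stands highest; the one step known is a number 13 percentage points higher from compound 1 to compound 2 (beyond the scatter), a change on the same sulfonyl sulfur. Compound 3, `CC1CCN(c2c(S(=O)(=O)c3ccc(C#N)cc3)cnc3ccc(F)cc23)CC1`, differs from compound 2 in that (4-cyanophenyl in place of 3,4-difluorophenyl on a sulfonyl sulfur). That step only loosely resembles the measured one, so the expected change is small: compound 3 is estimated to give 74%, within 52% to 90%, a step of a number 8 percentage points lower from compound 2 to compound 3 (within the scatter) that is not expected to exceed the scatter.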

Compound 3, a percentage reported as inhibition, at one concentration (the size of the read-out at that concentration, not a potency): 75%
Compound 3: middle estimate off by 1 percentage points, on the low side; low and high end bracket the measured number.
By their numbers in this assay, from the lowest: compounds 1, 3 and 2 (each within the scatter of the next, the first and the last beyond it).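

The sulfonyl sulfur accepts an aryl group carrying no halogen: replacing 3,4-difluorophenyl with 4-cyanophenyl in this assay gives a number 7 percentage points lower from compound 2 to compound 3 (within the scatter), and replacing 3,5-dichlorophenyl with it gives a number 6 percentage points higher from compound 1 to compound 3 (within the scatter). So a ring with a nitrile as its only substituent stays within the scatter of both halogenated rings, although those two differ beyond it. Nothing shown accounts for these readings.

Going by these compounds, whether an aminophenyl group, a carboxyphenyl group or an unsubstituted phenyl would read alike on this sulfur remains open. So does whether a longer alkyl chain could replace the ring there.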